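The source may report more compounds than this note shows. Statements on the series, on what has been measured and on what is new or still open speak of the compounds shown alone.

Compound 1 `CC[C@H](c1ccc(O)cc1)[C@@H](CC)c1ccc(OCC(O)CBr)cc1`: 0.5 h
Compound 2 `CC[C@H](c1ccc(O)cc1)[C@@H](CC)c1ccc(CBr)cc1`: 2.5 h
Compound 3 `CC[C@H](c1ccc(O)cc1)[C@@H](CC)c1ccc(C(=O)CCl)cc1`: 0.5 h

These numbers come from an ADME assay for pharmacokinetics; on this read-out lower numbers stand for a shorter-lived compound and higher numbers for a longer-lived compound. Compound 3 stands level with compound 1, and the two share the lowest number of the three. The next structure, compound 4 `CC[C@H](c1ccc(O)cc1)[C@@H](CC)c1ccc(OCC2CO2)cc1`, alters one group on the shared core: (oxiran-2-yl)methoxy in place of (chloromethyl)carbonyl on an aromatic carbon. The (oxiran-2-yl)methoxy group enters where the (chloromethyl)carbonyl group sat.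

All three measured steps bear on this change. Two involve compound 2, with a 5.0-fold higher number from compound 1 to compound 2 (0.70 log units; beyond the scatter) and a 5.0-fold lower number from compound 2 to compound 3 (0.70 log units; beyond the scatter). The third shows no change at the digits printed from compound 1 to compound 3 (within the scatter), so two different groups gave the same reading. The closest guide is compound 1, which also attaches its chain through an oxygen and gives 0.5 h. Going by the values given here, no measured compound carries the three-membered ring, so some uncertainty remains, mostly upward.

No step beyond the scatter is expected, and the estimate is a 1.4-fold higher number from compound 3 to compound 4 (0.15 log units; within the scatter). Compound 4 is expected to give 0.7 h, with an estimated range of 0.3 h to 1.8 h.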

Compound 4, half-life: 4 h
Compound 4: the middle estimate sits 5.7-fold (0.76 log units) below what was measured; the whole stated range lies below it.
By their numbers in this assay, from the lowest: compounds 1 and 3 (each within the scatter of the next); then compounds 2 and 4 (each within the scatter of the next).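

In this assay, holding the oxygen link in place does not fix the reading: with oxiran-2-yl in place of 2-bromo-1-hydroxyethyl on a saturated chain carbon bound to an oxygen on an aromatic ring, the data show an 8.0-fold higher number from compound 1 to compound 4 (0.90 log units; beyond the scatter). Putting (oxiran-2-yl)methoxy in place of (chloromethyl)carbonyl gives an 8.0-fold higher number from compound 3 to compound 4 (0.90 log units; beyond the scatter), while putting it in place of bromomethyl gives a 1.6-fold higher number from compound 2 to compound 4 (0.20 log units; within the scatter), so these two quite different groups are not separated at this position. No measurement shown accounts for any of these steps.

From the compounds shown here alone, whether the three-membered non-aromatic ring itself matters, or the whole (oxiran-2-yl)methoxy group, remains open. A plain methoxy group or a ring holding nitrogen in place of the oxygen could read like compound 4 or like compound 1.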